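Compound 4: replacing 4-(trifluoromethyl)phenyl with 3,4-dichlorophenyl

The source may hold more compounds than are shown below. What is called first, only, known or untested is meant among the compounds shown, and "the series" means these compounds.

- Compound 1 `COc1cc2ncnc(Nc3ccc(NC(=O)c4ccc(C)cc4)cc3)c2cc1OC`: 19000 nM
- Compound 2 `COc1cc2ncnc(Nc3ccc(NC(=O)c4ccc(F)cc4)cc3)c2cc1OC`: 27000 nM
- Compound 3 `COc1cc2ncnc(Nc3ccc(NC(=O)c4ccc(C(F)(F)F)cc4)cc3)c2cc1OC`: > 100000 nM

All three compounds were tested in a functional assay on MCF7 cells (Homo sapiens) for inhibition, read by MTT assay; a lower number here means a stronger inhibitor, a higher number a weaker inhibitor. Compound 3 stands at > 100000 nM, which is a limit of the assay and not a number.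

The next structure, compound 4 `COc1cc2ncnc(Nc3ccc(NC(=O)c4ccc(Cl)c(Cl)c4)cc3)c2cc1OC`, keeps the shared core and carries 3,4-dichlorophenyl in place of 4-(trifluoromethyl)phenyl on a carbonyl carbon.

Among the compounds with values here, three measured steps bear on this change. Fluoro in place of methyl gave a 1.4-fold higher number from compound 1 to compound 2 (0.15 log units; within the scatter). Trifluoromethyl in place of methyl gave an at least 5.2-fold higher number from compound 1 to compound 3 (0.72 log units; beyond the scatter), and trifluoromethyl in place of fluoro gave an at least 3.7-fold higher number from compound 2 to compound 3 (0.56 log units; beyond the scatter). Among these three compounds, only the one with trifluoromethyl reached the limit.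

Compound 4 has no trifluoromethyl, so a lower number is expected in this assay, closer to compound 1 and compound 2. Within the data shown here, no compound with chlorine has been measured, so the range stays wide and reaching the limit remains possible. The expected change is an at least 3.3-fold lower number from compound 3 to compound 4 (0.52 log units; beyond the scatter). Compound 4 is estimated at 30000 nM, with an expected range of 10000 nM to 100000 nM.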

Compound 4, half-maximal inhibitory concentration: 25000 nM
The estimate for compound 4 lay 1.2-fold (0.08 log units) above the measured number; the measured number falls inside the stated range.
By their numbers in this assay, from the lowest: compounds 1, 4 and 2 (each within the scatter of the next). At a limit, above all of these: compound 3.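

The change to 3,4-dichlorophenyl on the carbonyl carbon gives an at least 4.0-fold lower number from compound 3 to compound 4 (0.60 log units; beyond the scatter), which shows that chlorine on this ring does not push the number up the way trifluoromethyl did. Set against the other two rings, it gives a 1.1-fold lower number from compound 2 to compound 4 (0.03 log units; within the scatter) and a 1.3-fold higher number from compound 1 to compound 4 (0.12 log units; within the scatter), so 3,4-dichlorophenyl, 4-fluorophenyl and 4-methylphenyl cannot be told apart at this position. Among the four compounds, compound 3 therefore stays alone at a limit of the assay, which is not a number: the limit of > 100000 nM in this assay, at which 1 of the 4 values shown sits.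

As far as these compounds go, all four rings here carry only halogen, methyl or trifluoromethyl groups, so it stays open how a ring bearing an amine or a carboxylic acid would read. Also open, from the compounds shown here alone, is whether any group at this position can give a clearly lower number than compound 1, at 19000 nM.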